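One ring swap on a carbonyl carbon

A few compounds are considered here, and "the series" means these few. Any claim that something is new, unique, unknown or untested is made for them only; others in the source may bear on it.

Compound 1 `Nc1ncc(-c2ccc(C(=O)N3CCC(O)C3)cc2)nc1-c1ccc(C(F)(F)F)cc1` gives 77000 nM as its value
Compound 2 `Nc1ccc(-c2nc(-c3ccc(S(=O)(=O)C4CC4)cc3)cnc2N)cn1` gives 13000 nM as its value

In a physicochemical assay for solubility, read by HPLC, using the shake flask method, in phosphate buffer, with a stated time of 2 h, at pH 6.5 (on this read-out lower numbers stand for lower solubility and higher numbers for higher solubility), compound 1 stands highest of the two measured compounds at 77000 nM and compound 2 sits lower at 13000 nM with a gap beyond the scatter. These two differ in more than one place, so their gap offers no guide to a single change. Compound 3 `Nc1ncc(-c2ccc(C(=O)N3CCC(O)CC3)cc2)nc1-c1ccc(C(F)(F)F)cc1` departs from compound 1 in one place, with 4-hydroxypiperidin-1-yl in place of 3-hydroxypyrrolidin-1-yl on a carbonyl carbon as the counted difference: 4-hydroxypiperidin-1-yl in place of 3-hydroxypyrrolidin-1-yl on a carbonyl carbon. For the measured compounds named here, no measured pair shows this or any other single change, so what follows is judgement alone. In this assay a modest drop is expected, most likely none beyond the scatter, and the estimated step is a 1.5-fold lower number from compound 1 to compound 3 (0.19 log units; within the scatter) in size. For compound 3 the estimated value is 50000 nM with an expected range from 15000 nM to 130000 nM in this measurement.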

Compound 3, solubility: 19000 nM
Beside the measured number, compound 3's estimate is 2.6-fold (0.42 log units) above it, and the stated range covers the measured number.
By their numbers in this assay, from the lowest: compounds 2 and 3 (each within the scatter of the next); then compound 1.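

In this assay, for the compounds shown here, the swap of 3-hydroxypyrrolidin-1-yl for 4-hydroxypiperidin-1-yl on a carbonyl carbon gives a 4.1-fold lower number from compound 1 to compound 3 (0.61 log units; beyond the scatter) on the shared core, the first step here that belongs to a single place in the structure. It shows that this position is not silent in this measurement: a swap from a five-membered to a six-membered non-aromatic ring moves the number beyond the scatter, though the counted hydrogen-bond donor and acceptor stay the same. No measurement at hand bears on what lies behind this step.

The compounds shown leave open whether the step follows the ring size or the place of the hydroxy group, which 3-hydroxypiperidin-1-yl would separate. On these data alone, how morpholin-4-yl or piperazin-1-yl on the same carbonyl carbon would read in this assay also stays open.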